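A few compounds are considered here, and "the series" means these few. Any claim that something is new, unique, unknown or untested is made for them only; others in the source may bear on it.

Three compounds share one core, and the series is read in a functional assay on MCF7 cells (Homo sapiens) for cytotoxicity, read by MTT assay, with a stated time of 72 h; a lower number here means a stronger inhibitor, a higher number a weaker inhibitor. Compound 1 `COc1cccc(/C=C2\CCC/C(=C\c3cccc(O)c3)C2=O)c1OC` gives 8800 nM. Compound 2 `COc1ccc(/C=C2\CCC/C(=C\c3ccc(Br)cc3)C2=O)cc1OC` gives 6900 nM, the second highest of the three numbers; its nearest neighbour is compound 1, and its furthest is compound 3 `COc1cc(/C=C2\CCC/C(=C\c3ccc(OC)c(OC)c3)C2=O)cc(OC)c1`, which gives 3900 nM. Both of those gaps lie within the scatter of repeated measurements. Compound 4 `COc1ccc(/C=C2\CCC/C(=C\c3ccc(O)c(Cl)c3)C2=O)cc1OC` has not yet been measured. It differs from compound 2 by 3-chloro-4-hydroxyphenyl in place of 4-bromophenyl on a double-bonded chain carbon bound to a double-bonded ring carbon. Within the data shown here, no pair of measured compounds isolates this change, so only the three numbers guide the expectation, and they spread little. Compound 4 is expected to give 5500 nM, between 2000 nM and 15000 nM. The expected step is a 1.3-fold lower number from compound 2 to compound 4 (0.10 log units; within the scatter), no larger than the scatter.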

Compound 4, half-maximal inhibitory concentration: 12300 nM
Compound 4: the middle estimate sits 2.2-fold (0.35 log units) below what was measured; the measured number falls inside the stated range.
By their numbers in this assay, from the lowest: compounds 3, 2, 1 and 4 (each within the scatter of the next, the first and the last beyond it).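

In this assay, among these compounds, the replacement of 4-bromophenyl by 3-chloro-4-hydroxyphenyl on a double-bonded chain carbon bound to a double-bonded ring carbon gives a 1.8-fold higher number from compound 2 to compound 4 (0.25 log units; within the scatter), the first step that isolates one place. The step stays within the scatter, so this place accepts a ring carrying a hydrogen-bond donor and acceptor without the two compounds being told apart. Nothing available explains the result. The compounds shown do not separate the contribution of the chlorine from that of the hydroxy group. Going by these compounds, whether an amine or a carboxylic acid on this ring would give a step beyond the scatter remains open.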